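Ethyl to cyclopropyl on the sulfonyl sulfur: half-life notes

The source may hold more compounds than are shown below. What is called first, only, known or untested is meant among the compounds shown, and "the series" means these compounds.

Measured so far in an ADME assay on the whole organism for metabolic stability, with Rattus norvegicus as the target; a lower number here means that the compound disappears faster, a higher number that the compound lasts longer
- compound 1 `CCC(=O)Nc1n[nH]c2c1CN([C@H]1CO[C@H](c3cc(F)ccc3F)[C@@H](N)C1)C2` gives 2.2 h
- compound 2 `CS(=O)(=O)Nc1n[nH]c2c1CN([C@H]1CO[C@H](c3cc(F)ccc3F)[C@@H](N)C1)C2` gives 2 h
- compound 3 `CCS(=O)(=O)Nc1n[nH]c2c1CN([C@H]1CO[C@H](c3cc(F)ccc3F)[C@@H](N)C1)C2` gives 2.1 h

Compound 3 stands at 2.1 h and cannot be told apart from compound 1 or compound 2 on these numbers. Compound 4 `N[C@H]1C[C@@H](N2Cc3[nH]nc(NS(=O)(=O)C4CC4)c3C2)CO[C@@H]1c1cc(F)ccc1F` differs from compound 3 in one place cyclopropyl in place of ethyl on a sulfonyl sulfur and carries cyclopropyl in place of ethyl on a sulfonyl sulfur.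

The closest measured change is methyl in place of hydrogen on a saturated chain carbon bound to a sulfonyl sulfur, which gave a 1.1-fold higher number from compound 2 to compound 3 (0.02 log units; within the scatter) as its result. The swaps from propanoyl gave a 1.1-fold lower number from compound 1 to compound 2 (0.04 log units; within the scatter) and a 1.0-fold lower number from compound 1 to compound 3 (0.02 log units; within the scatter) with no change beyond the scatter. Among the compounds with values here, no measured compound carries a ring on that sulfur, so the range is kept wide.

On the evidence of a 1.1-fold higher number from compound 2 to compound 3 (0.02 log units; within the scatter) no step beyond the scatter is expected in this assay for this change. For compound 4 the estimated step is a 1.0-fold higher number from compound 3 to compound 4 (0.02 log units; within the scatter) in this measurement. For compound 4 the estimated value is 2.2 h with an expected range from 1.4 h to 3.4 h in this measurement.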

Compound 4, half-life: 1.5 h
Compound 4: middle estimate off by 1.5-fold (0.17 log units), on the high side; the measured number falls inside the stated range.
By their numbers in this assay, from the lowest: compounds 4, 2, 3 and 1 (each within the scatter of the next).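

In this assay, a three-membered ring on the sulfonyl sulfur now joins the earlier chains, and cyclopropyl in place of ethyl stays within the scatter (a 1.4-fold lower number from compound 3 to compound 4 (0.15 log units; within the scatter)), as does cyclopropyl in place of methyl (a 1.3-fold lower number from compound 2 to compound 4 (0.12 log units; within the scatter)). The step away from the propanoyl group also stays within the scatter (a 1.5-fold lower number from compound 1 to compound 4 (0.17 log units; within the scatter)), so neither the propanoyl group nor any of the sulfonyl groups shown can be separated from the others by half-life. Nothing available explains these numbers.

As far as these compounds go, whether a larger ring such as cyclobutyl, a longer chain such as butyl, or a chain ending in an amine on the sulfonyl sulfur would move the half-life beyond the scatter remains open. From the compounds shown here alone, all four compounds share one core, so whether the same flat result holds on a different core also remains open.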